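Bromo-to-methyl swap at the arylidene of the series

The compounds below may be only part of what the source reports. "The series", "measured", "known", "first", "only" and "open" are said of these compounds alone.

Measured so far in a functional assay on A549 cells (Homo sapiens) for cytotoxicity, read by CCK-8 assay, with a stated time of 72 h; on this read-out higher numbers stand for weaker inhibition and lower numbers for stronger inhibition:
- compound 1 `C=CCn1c(=O)/c(=C\c2cccc(Cl)c2)[nH]c(=O)/c1=C\c1ccccc1OC`: 5200 nM
- compound 2 `C=CCn1c(=O)/c(=C\c2ccccc2OC)[nH]c(=O)/c1=C\c1ccccc1OC`: 22400 nM
- compound 3 `C=CCn1c(=O)/c(=C\c2cccc(Br)c2)[nH]c(=O)/c1=C\c1ccccc1OC`: 5400 nM

Among the three measured compounds, compound 3 gives the second highest number; compound 1 sits nearest to it and compound 2 furthest. The two measured steps that reach compound 3 are a 1.0-fold higher number from compound 1 to compound 3 (0.02 log units; within the scatter) and a 4.1-fold lower number from compound 2 to compound 3 (0.62 log units; beyond the scatter). Among the compounds with values here, the only other step is a 4.3-fold higher number from compound 1 to compound 2 (0.63 log units; beyond the scatter).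

Compound 4 `C=CCn1c(=O)/c(=C\c2ccc(C)cc2)[nH]c(=O)/c1=C\c1ccccc1OC` differs from compound 3 by 4-methylphenyl in place of 3-bromophenyl on a double-bonded chain carbon bound to an aromatic carbon. Within the data shown here, no measured step covers a methyl at that ring, so the bearing steps are indirect: the halogen exchange was within the scatter, while exchanging the whole ring for 2-methoxyphenyl moved this assay by a modest amount. A change of the ring substituent is therefore expected to produce at most a modest step upward, since the only unhalogenated ring measured so far gave the weakest number. Compound 4 is expected to give 9000 nM (range 3500 nM to 25000 nM). The estimated step of a 1.7-fold higher number from compound 3 to compound 4 (0.22 log units; within the scatter) is thus modest and toward weaker inhibition.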

Compound 4, half-maximal inhibitory concentration: "not active" (no number reported)
Compound 4: no number reported, and the estimate cannot be compared.
By their numbers in this assay, from the lowest: compounds 1 and 3 (each within the scatter of the next); then compound 2.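

Within the data shown here, compound 4 is recorded as "not active" in this assay with no number, so no step to compound 1, compound 2 or compound 3 can be read. Nothing available bears on this result.

The compounds shown leave open whether the methyl group or its ring position governs the outcome for compound 4.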